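The compounds below may be only part of what the source reports. "The series", "measured", "known", "first", "only" and "open" are said of these compounds alone.

The account starts from compound 1, `O=C(CSc1nc2cccnc2[nH]1)Nc1ccccc1Cl`, whose thioether-linked amide carries a chlorine on the aniline ring. Among the compounds with values here, in an assay on isolated protein for inhibition of Ectonucleotide pyrophosphatase/phosphodiesterase family member 1 (Homo sapiens), tested at 10 uM (on this read-out lower numbers stand for less inhibition and higher numbers for more inhibition at the one concentration tested (going by the name of the read-out)), compound 1 gives 19%, the higher of the two numbers known so far. Within the data shown here, its only measured neighbour is compound 2, `Cc1ccc(NC(=O)CSc2nc3cccnc3[nH]2)c(Cl)c1`, which in this assay gives 2%; the step of a number 17 percentage points lower from compound 1 to compound 2 (beyond the scatter) came with a methyl in place of hydrogen on an aromatic carbon and is the sole measured step available.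

The compound now in question is compound 3, `O=C(CSc1nc2cccnc2[nH]1)Nc1ccccc1F`. Compared with compound 1 the difference is fluoro in place of chloro on an aromatic carbon. Among the measured compounds shown here, no measured step touches the chloro position itself, so the step from compound 1 to compound 2 offers no direct guide, only a reminder that a one-atom change elsewhere on this ring moved the number beyond the scatter. With so little to go on, the expectation for compound 3 is a number near that of compound 1 or somewhat lower, a step of a number 6 percentage points lower from compound 1 to compound 3 (within the scatter) that need not exceed the scatter. Compound 3 is therefore estimated at 13%, within 0% to 32%.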

Compound 3, a percentage reported as inhibition, at one concentration (the size of the read-out at that concentration, not a potency): 13%
Estimate against measurement, compound 3: no gap at the digits printed, and the stated range covers the measured number.
By their numbers in this assay, from the lowest: compound 2; then compounds 3 and 1 (each within the scatter of the next).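

Within the data shown here, compound 3 gives the first measured change at the halogen itself, a swap from 2-chlorophenyl to 2-fluorophenyl, and in this assay this swap is a number 6 percentage points lower from compound 1 to compound 3 (within the scatter) and so cannot be told apart from no change. On this aromatic carbon, ortho to a large group, the exchange of chloro for fluoro therefore stays inside the usual scatter, whereas the methyl in place of hydrogen elsewhere on the same ring gave a number 17 percentage points lower from compound 1 to compound 2 (beyond the scatter) and went beyond it. Nothing at hand bears on why these two single-atom or single-group changes differ in size.

Among these compounds, compound 1 at 19% and compound 3 at 13% are the only halogen pair here, so it remains open whether an amine, a methoxy group or a carboxylic acid in this place would give a number clearly apart from theirs. From the compounds shown here alone, it is also open whether the methyl that accompanied the step to compound 2 would have a like effect on the 2-fluorophenyl ring of compound 3.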